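Iodo in place of piperidinyl on the pyridine-type ring

The source may hold more compounds than are shown below. What is called first, only, known or untested is meant among the compounds shown, and "the series" means these compounds.

Three compounds share one core. Compound 1 `CCCCN(CCC)c1cc(C)nc2c(-c3ncc(C(F)(F)F)cc3Cl)c(C)nn12` gives 1.2 nM in an assay on isolated protein for binding affinity to corticotropin-releasing factor receptor 1 (Homo sapiens); a higher number here means a weaker inhibitor, a lower number a stronger inhibitor. Compound 2 `CCCN(CCC)c1cc(C)nc2c(-c3ncc([N+](=O)[O-])cc3C)c(C)nn12` gives 9.1 nM, and compound 3 `CCCN(CCC)c1cc(C)nc2c(-c3ncc(N4CCCCC4)cc3C)c(C)nn12` gives 17 nM, the highest of the three numbers; compound 3 sits close to compound 2 but far from compound 1. The change to compound 4 `CCCN(CCC)c1cc(C)nc2c(-c3ncc(I)cc3C)c(C)nn12` is iodo in place of piperidin-1-yl on an aromatic carbon. Among the compounds with values here, only one measured step touches this position: a 1.9-fold higher number from compound 2 to compound 3 (0.27 log units; within the scatter), which changed little. Within the data shown here, no step swaps a ring for a halogen, so the expectation rests mainly on compound 1, whose trifluoromethyl at the same place gives 1.2 nM. A moderate fall in the number is expected, a 4.3-fold lower number from compound 3 to compound 4 (0.63 log units; beyond the scatter), so compound 4 is estimated at 4 nM, between 1.5 nM and 12 nM.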

Compound 4, inhibition constant: 6.6 nM
For compound 4 the middle estimate is 1.7-fold (0.22 log units) below the measured one; measured number inside the range.
By their numbers in this assay, from the lowest: compound 1; then compounds 4, 2 and 3 (each within the scatter of the next, the first and the last beyond it).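

At this place on the ring, iodo in place of piperidin-1-yl gives a 2.6-fold lower number from compound 3 to compound 4 (0.41 log units; beyond the scatter) in this assay as a modest change, so the piperidine ring is not needed to keep a number of this size. Iodo in place of nitro gives a 1.4-fold lower number from compound 2 to compound 4 (0.14 log units; within the scatter) and leaves these two groups indistinguishable here. Nothing available explains either step.

Open, from the compounds shown here alone, is how a carboxylic acid or a small amine such as dimethylamino would fare at this place. Going by these compounds, compound 1 differs from compound 4 in more than one place, so what its trifluoromethyl contributes alone stays unknown.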